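Cyano for methyl on the benzyl ester of compound 3

The source may hold more compounds than are shown below. What is called first, only, known or untested is meant among the compounds shown, and "the series" means these compounds.

Measured so far in an assay on isolated protein for inhibition of protein kinase C zeta type (Homo sapiens), with stated times of 1 h and 2.5 min, tested at 30 uM; on this read-out lower numbers stand for less inhibition and higher numbers for more inhibition at the one concentration tested (going by the name of the read-out):
compound 1, `CCOC(=O)c1c(-c2ccc(OC)c(OC)c2)csc1N`, 100%
compound 2, `COCCOC(=O)c1c(-c2ccc(OC)c(OC)c2)csc1N`, 57%
compound 3, `COc1ccc(-c2csc(N)c2C(=O)OCc2cccc(C)c2)cc1OC`, 67%

Compound 3 stands second of the three: compound 2 lies close to it, within the scatter a number 10 percentage points higher from compound 2 to compound 3 (within the scatter), while compound 1 lies well apart a number 33 percentage points lower from compound 1 to compound 3 (beyond the scatter). Compound 4, `COc1ccc(-c2csc(N)c2C(=O)OCc2cccc(C#N)c2)cc1OC`, differs from compound 3 by one change on the aromatic ring of the ester: cyano in place of methyl on an aromatic carbon. Among the compounds with values here, none of the measured steps touches that ring; the two large steps, a number 43 percentage points lower from compound 1 to compound 2 (beyond the scatter) and a number 33 percentage points lower from compound 1 to compound 3 (beyond the scatter), concern the chain carbon bound to the oxygen next to the carbonyl, so they give no guide here. With nothing to point either way, the expected step of a number 2 percentage points lower from compound 3 to compound 4 (within the scatter) stays within the scatter. Compound 4 is therefore estimated at 65%, with a range from 42% to 88%.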

Compound 4, a percentage reported as inhibition, at one concentration (the size of the read-out at that concentration, not a potency): 70%
Beside the measured number, compound 4's estimate is 5 percentage points below it; measured number inside the range.
By their numbers in this assay, from the lowest: compounds 2, 3 and 4 (each within the scatter of the next, the first and the last beyond it); then compound 1.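

In this assay, within the data shown here, the aromatic ring of the ester is changed for the first time, and cyano in place of methyl on this carbon gives a number 3 percentage points higher from compound 3 to compound 4 (within the scatter), so this position accepts either group with no step beyond the scatter. The 3-cyanobenzyl ester also gives a number 13 percentage points higher from compound 2 to compound 4 (beyond the scatter) and a number 30 percentage points lower from compound 1 to compound 4 (beyond the scatter), so the ester change still separates these compounds. No supporting data on the cause accompany these results.

As far as these compounds go, what an amine or a carboxylic acid would do on this aromatic carbon remains open. So does whether any group on this ring could close the gap to the ethyl ester.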